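The compounds below may be only part of what the source reports. "The series", "measured", "known", "first", "only" and "open" are said of these compounds alone.

Working notes on the series. Compound 1 `COc1cc(-c2ccnc3cc(-c4ccc(C(F)(F)F)cc4)nn23)cc(OC)c1OC` gives 2440 nM in a functional assay on MCF7 cells (Homo sapiens) for inhibition, read by CCK-8 assay, with a stated time of 48 h; on this read-out higher numbers stand for weaker inhibition and lower numbers for stronger inhibition. Compound 2 `COc1cc(-c2ccnc3cc(-c4cccc5c4ccn5CO)nn23)cc(OC)c1OC` gives 1070 nM in this assay, so compound 1 carries the higher of the two measured numbers, and the gap to compound 2, the nearest measured number, lies beyond the scatter. Compound 3 `CCOC(=O)c1ccc(-c2cc3nccc(-c4cc(OC)c(OC)c(OC)c4)n3n2)cc1` reaches only the limit of this assay, > 10000 nM, which is a limit and not a number. Among the measured compounds shown here, the step of an at least 4.0-fold higher number from compound 1 to compound 3 (0.61 log units; beyond the scatter) is the one measured change at the same place on the core of compound 1, and its far end sits at the limit (the limit of > 10000 nM in this assay, at which 1 of the 3 values shown sits).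

Compound 4 `COc1ccc(-c2cc3nccc(-c4cc(OC)c(OC)c(OC)c4)n3n2)cc1N` differs from compound 1 by 3-amino-4-methoxyphenyl in place of 4-(trifluoromethyl)phenyl on an aromatic carbon. For the measured compounds named here, the only step that bears on it is an at least 4.0-fold higher number from compound 1 to compound 3 (0.61 log units; beyond the scatter), which ran toward weaker inhibition when the trifluoromethyl was replaced; the entering 3-amino-4-methoxyphenyl with its 1 hydrogen-bond donor and 2 hydrogen-bond acceptors is a change of comparable kind, so a step toward weaker inhibition, expected as a 1.4-fold higher number from compound 1 to compound 4 (0.16 log units; within the scatter), seems the likelier outcome, though the evidence is a single step. Compound 4 is therefore expected to give about 3500 nM, within 900 nM to 12000 nM, in this assay.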

Compound 4, half-maximal inhibitory concentration: 27 nM
For compound 4 the middle estimate is 130-fold (2.11 log units) above the measured one; the measured number lies below the stated range.
By their numbers in this assay, from the lowest: compound 4; then compound 2; then compound 1. At a limit, above all of these: compound 3.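

This place on the core, an aromatic carbon of the five-membered ring next to the ring nitrogen, can carry a change in the aryl group that strengthens inhibition by a large margin: a 90-fold lower number from compound 1 to compound 4 (1.96 log units; beyond the scatter) in this assay. The earlier step, an at least 4.0-fold higher number from compound 1 to compound 3 (0.61 log units; beyond the scatter), ran the other way and ends at a limit, so replacing the 4-(trifluoromethyl)phenyl has no single direction across these compounds, and the outcome depends on the entering group. Nothing shown accounts for the size of the new step.

Since the amino and methoxy groups enter together, the compounds shown leave open how much of the step belongs to each, which a phenyl bearing only the amine or only the methoxy would separate. From the compounds shown here alone, whether an acetamide or a hydroxyl in place of the amine would hold the number also remains open.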